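Chain amine variation in the stilbene ether series

The source may hold more compounds than are shown below. What is called first, only, known or untested is meant among the compounds shown, and "the series" means these compounds.

Measured so far:
Compound 1 `CN(C)CCCCOc1ccccc1/C=C/c1ccccc1Cl`: in a functional assay on the whole organism with Mus musculus as the target, at a dose of 50 mg/kg by the oral route (on this read-out higher numbers stand for more inhibition at the one dose given (going by the name of the read-out) and lower numbers for less inhibition), compound 1 gives 50%.
Compound 2 `C(=C/c1ccccc1OCCCCN1CCCC1)\c1ccccc1`: compound 2 gives 87.5%.
Compound 3 `OC1CCN(CCCCOc2ccccc2/C=C/c2ccccc2)CC1`: compound 3 gives 50%.

Compound 3 is level with compound 1 at the digits shown, the two together the lowest of the three numbers; against compound 2 it sits lower, as the step of a number 37.5 percentage points lower from compound 2 to compound 3 (beyond the scatter) shows. Compound 4 `C(=C/c1ccccc1OCCCCN1CCNCC1)\c1ccccc1` carries the change (piperazin-1-yl in place of 4-hydroxypiperidin-1-yl on a saturated chain carbon, four bonds along the chain from an oxygen on an aromatic ring). Within the data shown here, no measured step exchanges these two rings directly; the only step at this place is a number 37.5 percentage points lower from compound 2 to compound 3 (beyond the scatter), between two rings of different size. The change here keeps ring size and the donor and acceptor counts, so no step beyond the scatter is expected in this assay. The expected step is a number 5 percentage points higher from compound 3 to compound 4 (within the scatter). Compound 4 is estimated at 55%, within 30% to 80%.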

Compound 4, a percentage reported as inhibition, in the whole organism at one dose (the size of the read-out at that dose, not a potency): 0%
The estimate for compound 4 lay 55 percentage points above the measured number; the whole stated range lies above it.
By their numbers in this assay, from the lowest: compound 4; then compounds 1 and 3 (each within the scatter of the next); then compound 2.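

At this saturated chain carbon, keeping a six-membered non-aromatic ring and the same donor and acceptor counts does not hold the level in this assay: piperazin-1-yl in place of 4-hydroxypiperidin-1-yl gives a number 50 percentage points lower from compound 3 to compound 4 (beyond the scatter). Against pyrrolidin-1-yl, the same group gives a number 87.5 percentage points lower from compound 2 to compound 4 (beyond the scatter), so ring size and these counts alone do not set the level at this position. Nothing at hand accounts for either step.

The compounds shown leave open where piperidin-1-yl, morpholin-4-yl or 4-methylpiperazin-1-yl would fall at this position. On these data alone, whether the same order holds on a longer chain also stays open.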